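The compounds below may be only part of what the source reports. "The series", "measured", "known", "first", "only" and "open" are said of these compounds alone.

Working notes on the series. Compound 1 `O=C(/C=C/C1=Cc2ccccc2OC1)c1ccccc1Br`, compound 2 `O=C(/C=C/C1=Cc2ccccc2OC1)c1cccc(Br)c1` and compound 3 `O=C(/C=C/C1=Cc2ccccc2OC1)c1ccc(Br)cc1` share one core and differ only in whether 2-bromophenyl, 3-bromophenyl or 4-bromophenyl sits on the carbonyl carbon. In a functional assay on the whole organism for inhibition, with Mus musculus as the target, with a stated time of 1 h, at a dose of 30 mg/kg by the intraperitoneal route (on this read-out higher numbers stand for more inhibition at the one dose given (going by the name of the read-out) and lower numbers for less inhibition), compound 1 gives 56.6%, compound 2 gives 51.7% and compound 3 gives 66%. The steps among them are a number 4.9 percentage points lower from compound 1 to compound 2 (within the scatter), a number 9.4 percentage points higher from compound 1 to compound 3 (within the scatter) and a number 14.3 percentage points higher from compound 2 to compound 3 (beyond the scatter); compound 3 thus holds the highest of the three numbers, separated beyond the scatter only from compound 2.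

Compound 4 `CN(C)c1ccc(C(=O)/C=C/C2=Cc3ccccc3OC2)cc1` is the next step from compound 3: dimethylamino in place of bromo on an aromatic carbon. Going by the values given here, none of the measured steps bears on this exchange, since all three only move bromo around the ring, and those steps were at most modest. Among the compounds with values here, with no precedent for dimethylamino in the set, no step beyond the scatter is expected in this assay, so the estimate for compound 4 is 58%, from 38% to 78%. The step this estimate implies is expected to be a number 8 percentage points lower from compound 3 to compound 4 (within the scatter).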

Compound 4, a percentage reported as inhibition, in the whole organism at one dose (the size of the read-out at that dose, not a potency): 57.3%
Compound 4: middle estimate off by 0.7 percentage points, on the high side, and the stated range covers the measured number.
By their numbers in this assay, from the lowest: compounds 2, 1, 4 and 3 (each within the scatter of the next, the first and the last beyond it).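

In this assay, the exchange of bromo for dimethylamino on an aromatic carbon, para to a large group, gives a number 8.7 percentage points lower from compound 3 to compound 4 (within the scatter). Going by these compounds alone, the earlier compounds varied only where bromo sat on the ring, whereas this is the first change of the group itself, and at this position the read-out does not separate bromo from dimethylamino, a group of 3 heavy atoms with 1 hydrogen-bond acceptor in place of 1 heavy atom with none. Nothing at hand explains how these two groups come to read alike.

As far as these compounds go, it remains open whether a carboxylic acid, a methoxy group or a longer amine chain would read alike at this position. Also open, from the compounds shown here alone, is how dimethylamino would read in the places that bromo holds in compound 1 and compound 2, and a reading at one dose says nothing of potency.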